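Cyclopropane aryl variation in a receptor 88 agonist series

The compounds below may be only part of what the source reports. "The series", "measured", "known", "first", "only" and "open" are said of these compounds alone.

Measured so far in a functional assay for agonist activity at G protein-coupled receptor 88 (Homo sapiens), read by HTRF and cAMP accumulation; on this read-out higher numbers stand for an effect only at larger amounts of compound and lower numbers for an effect already at smaller amounts:
Compound 1, `CC[C@H](C)[C@H](N)CN(C(=O)[C@@H]1C[C@H]1c1cccc(Cl)c1)c1ccc(-c2ccccc2)cc1`: compound 1 gives 2200 nM.
Compound 2, `CC[C@H](C)[C@H](N)CN(C(=O)[C@@H]1C[C@H]1c1ccc(C#N)cc1)c1ccc(-c2ccccc2)cc1`: compound 2 reaches only the limit of the assay, > 25000 nM, not a number.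
Compound 3, `CC[C@H](C)[C@H](N)CN(C(=O)[C@@H]1C[C@H]1c1cccnc1)c1ccc(-c2ccccc2)cc1`: compound 3 gives 1500 nM.

Compound 3 holds the lowest of the two numbers, but the step of a 1.5-fold lower number from compound 1 to compound 3 (0.17 log units; within the scatter) lies within the scatter, so no order between the two is claimed. Compound 2 sits at the limit (the limit of > 25000 nM in this assay, at which 1 of the 3 values shown sits); the step of an at least 16-fold lower number from compound 2 to compound 3 (1.22 log units; beyond the scatter) is large, as is an at least 11-fold higher number from compound 1 to compound 2 (1.05 log units; beyond the scatter).

Compound 4, `CC[C@H](C)[C@H](N)CN(C(=O)[C@@H]1C[C@H]1c1csc(C)n1)c1ccc(-c2ccccc2)cc1`, differs from compound 3 by 2-methyl-1,3-thiazol-4-yl in place of pyridin-3-yl on a saturated ring carbon. For the measured compounds named here, no measured step involves a five-membered aromatic ring, so the bearing is indirect: compound 1 and compound 3 show that two different six-membered aromatic groups give numbers within the scatter of each other, while compound 2 shows that a 4-cyanophenyl group drops activity to the limit. Compound 4 is expected to land near compound 3 or somewhat higher, a step of a 2.0-fold higher number from compound 3 to compound 4 (0.30 log units; within the scatter). The estimate for compound 4 is 3000 nM, within 800 nM to 15000 nM, with some chance of a limit.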

Compound 4, half-maximal effective concentration: 1500 nM
Beside the measured number, compound 4's estimate is 2.0-fold (0.30 log units) above it; measured number inside the range.
By their numbers in this assay, from the lowest: compounds 3, 4 and 1 (each within the scatter of the next). At a limit, above all of these: compound 2.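

On this saturated ring carbon, a five-membered aromatic ring in the form of 2-methyl-1,3-thiazol-4-yl does as well as the six-membered aromatic groups in this assay, with no change at the digits printed from compound 3 to compound 4 (within the scatter) and a 1.5-fold lower number from compound 1 to compound 4 (0.17 log units; within the scatter). The gap to 4-cyanophenyl is large, at an at least 16-fold lower number from compound 2 to compound 4 (1.22 log units; beyond the scatter), so among the four groups shown only 4-cyanophenyl stands apart, while compounds 1, 3 and 4 lie within the scatter of one another. The value of compound 2 is a limit, not a number: the limit of > 25000 nM in this assay, at which 1 of the 4 values shown sits.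

Still open, as far as these compounds go, is whether the loss with 4-cyanophenyl goes with the nitrile or with where it sits on the ring, which 3-cyanophenyl and 4-chlorophenyl would separate. Also open, from the compounds shown here alone, is what the methyl group of 2-methyl-1,3-thiazol-4-yl contributes, which the unsubstituted 1,3-thiazol-4-yl would show.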